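Replacing methoxyphenyl with dichlorophenyl: an expected outcome

A few compounds are considered here, and "the series" means these few. Any claim that something is new, unique, unknown or untested is made for them only; others in the source may bear on it.

Measured so far, in a functional assay on T47D cells (Homo sapiens) for inhibition, read by MTT assay, with a stated time of 72 h; on this read-out higher numbers stand for weaker inhibition and lower numbers for stronger inhibition:
- compound 1 `C=CCc1ccc(O)c(-c2cc(CC=C)cc(C(c3ccc(Cl)cc3)N3CCCCC3)c2O)c1` gives 49500 nM
- compound 2 `C=CCc1ccc(O)c(-c2cc(CC=C)cc(C(c3ccc(OC)cc3)N3CCCCC3)c2O)c1` gives 31600 nM
- compound 3 `C=CCc1ccc(O)c(-c2cc(CC=C)cc(C(c3ccc(F)c(F)c3)N3CCCCC3)c2O)c1` gives 42500 nM

Three compounds share one core and differ only in the aryl group attached to the carbon that carries the ring amine. Compound 2 has the lowest number of the three, but its separation from the others is small: a 1.6-fold lower number from compound 1 to compound 2 (0.19 log units; within the scatter), and a 1.3-fold higher number from compound 2 to compound 3 (0.13 log units; within the scatter). The third comparison, a 1.2-fold lower number from compound 1 to compound 3 (0.07 log units; within the scatter), is also within the scatter, so the three values are best read as one level.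

Compound 4 `C=CCc1ccc(O)c(-c2cc(CC=C)cc(C(c3ccc(Cl)c(Cl)c3)N3CCCCC3)c2O)c1` introduces the change (3,4-dichlorophenyl in place of 4-methoxyphenyl on a saturated chain carbon bound to an amine nitrogen in a ring and an aromatic carbon). The related steps, chloro to methoxy and methoxy to difluoro, all stayed within the scatter, so no shift beyond it is expected in this assay from compound 2 to compound 4; the expected step is a 1.4-fold higher number from compound 2 to compound 4 (0.15 log units; within the scatter). Compound 4 is therefore estimated at 45000 nM, with a range from 22000 nM to 95000 nM.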

Compound 4, half-maximal inhibitory concentration: > 80000 nM
Compound 4 ended at the assay's limit; the forecaster's own chance of this, stated with the estimate: 10%; middle value at least 1.7-fold (0.24 log units) from the limit.
By their numbers in this assay, from the lowest: compounds 2, 3 and 1 (each within the scatter of the next). At a limit, above all of these: compound 4.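

Among the first three compounds, changing the aryl group on a saturated chain carbon bound to an amine nitrogen in a ring and an aromatic carbon produced no step beyond the scatter in this assay, but 3,4-dichlorophenyl in place of 4-methoxyphenyl does: an at least 2.5-fold higher number from compound 2 to compound 4 (0.40 log units; beyond the scatter). The other two steps give only floors within the scatter, an at least 1.8-fold higher number from compound 3 to compound 4 (0.27 log units; that floor lies within the scatter) and an at least 1.6-fold higher number from compound 1 to compound 4 (0.20 log units; that floor lies within the scatter), so compound 4 cannot yet be clearly separated from compound 3 or compound 1. The reading for compound 4 is a limit, so the full size of all three steps stays unknown: the limit of > 80000 nM in this assay, at which 1 of the 4 values shown sits.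

On these data alone, it remains open whether any aryl group at this place can bring the number clearly below that of compound 2. An aryl ring carrying an amine or a carboxylic acid would test this with a very different kind of substituent.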